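This account rests on a few compounds, and the source may have more. Where it says the series, first, only, none or still open, it means among the compounds named here.

Measured so far:
compound 1 `CN(C)CC1CCCc2cc(S(=O)(=O)c3ccccc3)ccc21` gives 0.0631 nM
compound 2 `NC[C@@H]1CCCc2cc(S(=O)(=O)c3c[nH]c4ccccc34)ccc21` gives 0.0501 nM
compound 3 `O=S(=O)(c1cccc(F)c1)c1ccc2c(c1)CCC[C@H]2CN1CCCS1(=O)=O` gives 31.6 nM

All three numbers come from an assay on isolated protein for displacement of a labelled ligand from 5-hydroxytryptamine receptor 6 (Homo sapiens); a lower number here means a stronger inhibitor, a higher number a weaker inhibitor. Among them compound 3 has the highest number, which makes it the weakest binder of the three: the values of compound 1 and compound 2 lie far below it, well beyond the scatter of repeated measurements. Within the data shown here, those two compounds differ from compound 3 in more than one place, so no single step to either of them can be read off.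

Compound 4 `NC(=O)NC[C@@H]1CCCc2cc(S(=O)(=O)c3cccc(F)c3)ccc21` has not yet been measured. It is compound 3 with one change: a group of 4 heavy atoms (1 carbon, 2 nitrogen, 1 oxygen; no ring) in place of a group of 7 heavy atoms (3 carbon, 1 nitrogen, 2 oxygen, 1 sulfur; one five-membered non-aromatic ring with 2 hetero atoms), on a saturated chain carbon bound to a saturated ring carbon Both the group that leaves and the group that enters carry no net charge.

Among the measured compounds shown here, no measured pair shows what this exchange does on its own, so there is no direct guide to the size of the step. Given that absence, the step from compound 3 to compound 4 is expected to be modest and could fall in either direction, most likely within or only slightly beyond the scatter. For compound 4 the expected value is 25 nM, with a range from 3 nM to 200 nM. This estimate corresponds to an expected step of a 1.3-fold lower number from compound 3 to compound 4 (0.10 log units; within the scatter).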

Compound 4, inhibition constant: 0.2 nM
Estimate against measurement, compound 4: 130-fold (2.10 log units) above; the measured number lies below the stated range.
By their numbers in this assay, from the lowest: compounds 2 and 1 (each within the scatter of the next); then compound 4; then compound 3.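

In this assay, among these compounds, putting ureido in place of the five-membered ring group on a saturated chain carbon bound to a saturated ring carbon gives a 160-fold lower number from compound 3 to compound 4 (2.20 log units; beyond the scatter), so what this position carries can change binding strongly, which the earlier compounds could not show because no measured pair isolated it. Neither group carries a net charge, so this large step comes without any change in net charge, while the entering group is smaller, has no ring and has hydrogen-bond donors where the leaving group has none. This single pair cannot separate those differences, and nothing measured here explains the step.

Going by these compounds, compound 1 and compound 2 each differ from compound 4 in more than one place, so those steps cannot be read, and what a simple amine would give on the exact frame of compound 4 stays open. Also open, on these data alone, is whether an acetamide or a carboxylic acid at the same place would give a number as low as compound 4 does at 0.2 nM, or whether this result belongs to ureido alone.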